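The compounds below may be only part of what the source reports. "The series", "measured", "known", "first", "only" and "open" are said of these compounds alone.

Measured compounds in a functional assay on HOP-92 cells (Homo sapiens) for inhibition, read by sulforhodamine B assay, with a stated time of 48 h; on this read-out lower numbers stand for stronger inhibition of growth and higher numbers for weaker inhibition of growth:
compound 1 `COc1ccc(CNc2nc3cc(N)cc(N)c3nc2-c2ccccc2)cc1OC`: 29500 nM
compound 2 `CCOC(=O)[C@H](CCC(=O)O)NC(=O)c1ccc(Sc2nc3cc(N)cc(N)c3nc2-c2ccccc2)cc1`: 23400 nM
compound 3 `COc1cc(CNc2nc3cc(N)cc(N)c3nc2-c2ccccc2)cc(OC)c1OC`: 3090 nM

Compound 1 gives the highest of the three numbers in this assay. Compound 2 sits nearest to it, and the two values lie within the scatter of each other, so nothing separates them. Compound 3 is furthest away: a 9.5-fold lower number from compound 1 to compound 3 (0.98 log units; beyond the scatter), a modest step; the structural change in that pair is a methoxy in place of hydrogen on an aromatic carbon of the side arm.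

The new compound 4 `Nc1cc(N)c2nc(-c3ccccc3)c(NCc3ccc(F)cc3)nc2c1` differs from compound 1 in that same arm: 4-fluorophenyl in place of 3,4-dimethoxyphenyl on a saturated chain carbon bound to a nitrogen on an aromatic ring. Going by the values given here, no measured pair covers this exact exchange. Among the compounds with values here, the only step touching the same arm is the one from compound 1 to compound 3, where an added methoxy lowered the number; compound 4 instead loses both methoxy groups of compound 1 and carries a fluorine in their stead. Read in reverse, that step would argue for a somewhat higher number, but the exchange is not the same and a single step is a thin basis, so the expected move is small and uncertain. The estimate is a 1.4-fold higher number from compound 1 to compound 4 (0.13 log units; within the scatter), a shift toward weaker growth inhibition that may well stay within the scatter. For compound 4 the expected value in this assay is 40000 nM, with a range from 12000 nM to 120000 nM.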

Compound 4, concentration for total growth inhibition: 6920 nM
Compound 4: the middle estimate sits 5.8-fold (0.76 log units) above what was measured; the whole stated range lies above it.
By their numbers in this assay, from the lowest: compound 3; then compound 4; then compounds 2 and 1 (each within the scatter of the next).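

In this assay, the arm on the saturated chain carbon bound to a nitrogen on an aromatic ring now shows a second change beyond the scatter, with 4-fluorophenyl in place of 3,4-dimethoxyphenyl: a 4.3-fold lower number from compound 1 to compound 4 (0.63 log units; beyond the scatter). Methoxy groups on this arm are thus not needed for a lower number: the earlier step, a 9.5-fold lower number from compound 1 to compound 3 (0.98 log units; beyond the scatter), came from adding a methoxy, yet compound 4 carries none and also lies below compound 1, so the number of methoxy groups alone does not order these three compounds, with compound 1 going against any such trend. No measured evidence here bears on why this exchange lowers the number.

With no plain phenyl on this arm among the compounds shown, the part played by the fluorine cannot be separated from the part played by losing both methoxy groups. Also open, from the compounds shown here alone, is how this arm would read with an amine or a carboxylic acid on its aromatic ring, or with a longer chain in place of the saturated chain carbon.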